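Mirror Image of Compound 1 in Antiproliferative Screening

A few compounds are considered here, and "the series" means these few. Any claim that something is new, unique, unknown or untested is made for them only; others in the source may bear on it.

The compounds here share a bicyclic lactone core carrying a lactam-derived imine, and all three measured ones show no measurable effect in an ADME assay on McCoy cells (Mus musculus) for antiproliferative activity, read by sulforhodamine B assay, with a stated time of 48 h; on this read-out higher numbers stand for weaker inhibition and lower numbers for stronger inhibition. Compound 1 `CC(C)(C)OC(=O)NCCC[C@@H]1N=C2C[C@@H]3C[C@@H](C3(C)C)[C@]2(C)OC1=O` gives in this assay > 1200000 nM, which is a limit of the assay rather than a number. Compound 2 `C[C@H]1N=C2C[C@H]3C[C@H](C3(C)C)[C@@]2(C)OC1=O` gives in this assay > 1800000 nM, also a limit. Compound 3 `CC1(C)[C@H]2CC[C@]1(C)[C@H]1OC(=O)CN=C21` gives in this assay > 900000 nM, again a limit. So compound 1 stands among values that are all limits, with no measured step between any two compounds.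

Compound 4 `CC(C)(C)OC(=O)NCCC[C@H]1N=C2C[C@H]3C[C@H](C3(C)C)[C@@]2(C)OC1=O` differs from compound 1 only in configuration: the two compounds have the same atoms and bonds and differ only in configuration as drawn: 4 of 4 stereo elements differ (all stereocentres are inverted: mirror images); a stereocentre at a saturated ring carbon is drawn S in compound 1 and R in compound 4; a stereocentre at a saturated ring carbon is drawn S in compound 1 and R in compound 4; a stereocentre at a saturated ring carbon is drawn S in compound 1 and R in compound 4; a stereocentre at a saturated ring carbon is drawn S in compound 1 and R in compound 4. Within the data shown here, since compound 1 gives only a limit > 1200000 nM, no step in this assay beyond the scatter is expected in either direction; compound 4 is expected most likely to return a limit as well. The expected step from compound 1 to compound 4 is a number no higher from compound 1 to compound 4 (the limit leaves the size open). Compound 4 is therefore estimated at 1200000 nM, within a range from 400000 nM to 3000000 nM.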

Compound 4, half-maximal inhibitory concentration: > 1500000 nM
Compound 4: no number, only a limit; the forecaster's own chance of this, stated with the estimate: 85%; middle value at least 1.2-fold (0.09 log units) from the limit.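

Among these compounds, compound 1 and its mirror image, compound 4, each return only a limit in this assay, so no step between them can be read. The compounds shown leave open at what concentration, if any, either mirror form would inhibit these cells, and whether the two forms would differ.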